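The compounds below may be only part of what the source reports. "The series", "measured", "known", "first", "only" and "open" are said of these compounds alone.

Compound 1 `O=C(Nc1ccc(OC(F)F)cc1)c1cccc(/C=C2\CC(=O)N(c3ccccc3)C2=O)c1` was tested in an ADME assay on SW480 cells (Homo sapiens) for cytotoxicity, read by MTT assay, with a stated time of 72 h; a lower number here means a stronger inhibitor, a higher number a weaker inhibitor. In this assay compound 1 gives > 100000 nM, which is a limit of the assay. Compound 2 `CCCCCN1C(=O)C/C(=C\c2cccc(C(=O)Nc3ccc(OC)cc3)c2)C1=O` belongs to the same set. In this assay compound 2 gives > 100000 nM, again a limit of the assay. So compound 1 stands where every value shown stands: the limit of > 100000 nM in this assay, at which 2 of the 2 values shown sit, and no compound yet carries a plain number.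

Compound 3 `O=C(NCC1CCCCC1)c1cccc(/C=C2\CC(=O)N(c3ccccc3)C2=O)c1` has not yet been measured in this assay. Its structure differs from compound 1 in one place: cyclohexylmethyl in place of 4-(difluoromethoxy)phenyl on an amide-type nitrogen. Among the compounds with values here, no two measured compounds differ in only one place, so no measured step shows how a change of this kind moves the read-out. With compound 1 sitting at the limit, the change is expected to give no movement beyond the scatter, so compound 3 is expected to sit at or near the same limit. The step implied by this expectation, a number no higher from compound 1 to compound 3 (the limit leaves the size open), is expected to be small. Compound 3 is estimated at 100000 nM, within a range from 30000 nM to 300000 nM.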

Compound 3, half-maximal inhibitory concentration: > 100000 nM
Compound 3 gave a limit, no number (the forecaster's own chance of this, stated with the estimate: 80%); the middle value lies on the limit itself.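

No step can be read from compound 1 to compound 3, because both results are limits and not plain numbers: the limit of > 100000 nM in this assay, at which 3 of the 3 values shown sit. The compounds shown leave open whether cyclohexylmethyl in place of 4-(difluoromethoxy)phenyl on the amide-type nitrogen changes the read-out at all, and which structures, if any, would give a plain number.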